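The source may report more compounds than this note shows. Statements on the series, on what has been measured and on what is new or still open speak of the compounds shown alone.

Measured so far:

compound 1, `CCCC(=O)C1=C(C)NC(=O)NC1c1ccoc1`, 2%
compound 2, `CC1=C(C(=O)CC(C)C)C(c2ccoc2)NC(=O)N1`, 18%
compound 3, `CCNC(=O)C1=C(C)NC(=O)NC1c1ccsc1`, 1%

All three were tested in an assay on membranes from HeLa cells for displacement of a labelled ligand from adenosine receptor A3 (Homo sapiens), read by scintillation counting, with a stated time of 180 min, tested at 1 uM; a higher number here means more inhibition at the concentration tested (going by the name of the read-out), a lower number less inhibition. Compound 1 gives 2% there, and compound 2, which carries one extra methyl, gives 18%. The change between them is methyl in place of hydrogen on a saturated chain carbon bound to two saturated chain carbons, and it made a step of a number 16 percentage points higher from compound 1 to compound 2 (beyond the scatter).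

Compound 3 has a different core; the difference between the core of compound 1 and the core of compound 3 is not broken down here. In this assay compound 3 gives 1%, which sits within the scatter of compound 1.

Compound 4, `CC1=C(C(=O)NC(C)C)C(c2ccsc2)NC(=O)N1`, has not yet been measured. It differs from compound 3 by methyl in place of hydrogen on a saturated chain carbon bound to an amide-type nitrogen and a saturated chain carbon. Within the data shown here, this is the same kind of change as the one from compound 1 to compound 2, but the surroundings differ: there the methyl entered on a saturated chain carbon bound to two saturated chain carbons, here it enters on a saturated chain carbon bound to an amide-type nitrogen and a saturated chain carbon.

Among the measured compounds shown here, with only one earlier example of this kind of change, the expectation rests on it alone: since compound 2 rose over compound 1 by a number 16 percentage points higher from compound 1 to compound 2 (beyond the scatter), a rise of similar size is expected, a number 9 percentage points higher from compound 3 to compound 4 (within the scatter), though a smaller one would not be surprising. Compound 4 is therefore estimated at 10% in this assay, with a range from 0% to 25%.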

Compound 4, a percentage reported as inhibition, at one concentration (the size of the read-out at that concentration, not a potency): 1%
The estimate for compound 4 lay 9 percentage points above the measured number; the range from low to high includes it.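

In this assay, turning ethylcarbamoyl into isopropylcarbamoyl gives no change at the digits printed from compound 3 to compound 4 (within the scatter), so the gain seen on the other core does not appear here. A single methyl in place of hydrogen therefore cannot be counted on to do the same thing from one core to the other in this series, as the two cases differ: the same change on two cores in this assay, a number 16 percentage points higher (beyond the scatter) from compound 1 to compound 2 and no change at the digits printed (within the scatter) from compound 3 to compound 4, 16 percentage points apart, beyond the scatter of two such steps What this does not show is why they differ, since the two cases vary both in the core and in the surroundings of the methyl, which enters on a saturated chain carbon bound to an amide-type nitrogen in one case and on one bound to two saturated chain carbons in the other, and two examples cannot separate these.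

The compounds shown leave open whether any larger group in this spot would lift the number on the core of compound 3, for example a tert-butylcarbamoyl or a longer chain such as butylcarbamoyl. They also leave open how the same methyl behaves on further cores, so the size of the gain on the core of compound 1 remains a single observation.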